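Methyl on the Oxygen: Estimating the Next Compound

This account rests on a few compounds, and the source may have more. Where it says the series, first, only, none or still open, it means among the compounds named here.

Compound 1 `Nc1ccccc1/C=C/c1ccccc1O` — 27 ug/mL
Compound 2 `Nc1ccc(/C=C/c2cccc(O)c2)cc1` — 25 ug/mL

Of the compounds shown here, two have been measured in an ADME assay on HEK293 cells (Homo sapiens) for inhibition, read by MTT assay, with a stated time of 2 days; on this read-out lower numbers stand for stronger inhibition and higher numbers for weaker inhibition. Compound 1 gives 27 ug/mL, the higher of the two numbers, and compound 2 gives 25 ug/mL, a difference that sits within the usual scatter of this assay, so the two cannot be told apart on these data.

The next compound, compound 3 `COc1ccccc1/C=C/c1ccccc1N`, differs from compound 1 in one place: methyl in place of hydrogen on an oxygen on an aromatic ring, which reads as hydroxy to methoxy when the difference is cut one bond further out. Among the measured compounds shown here, no pair of measured compounds shows what such a change does here, so there is no step to lean on. Without a precedent, the expected step from compound 1 to compound 3 in this assay is small, likely a slight move toward a higher number or none beyond the scatter, estimated as a 1.3-fold higher number from compound 1 to compound 3 (0.11 log units; within the scatter). Compound 3 is therefore expected to give about 35 ug/mL, with a range from 15 ug/mL to 80 ug/mL.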

Compound 3, half-maximal inhibitory concentration: 2.1 ug/mL
Beside the measured number, compound 3's estimate is 17-fold (1.22 log units) above it; the measured number lies below the stated range.
By their numbers in this assay, from the lowest: compound 3; then compounds 2 and 1 (each within the scatter of the next).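

Putting methyl in place of hydrogen on this oxygen, the change from hydroxy to methoxy, gives a 13-fold lower number from compound 1 to compound 3 (1.11 log units; beyond the scatter) in this assay and is large, well beyond the scatter, so on this read-out it means stronger inhibition of the cells. Among the compounds shown here, compound 1 and compound 2 differ in more than one place, so they offered no step to read; this pair is the first to show that the group on this oxygen can strongly change the number while the rest of the structure stays the same. Nothing measured here explains why so small a change has so large an effect.

On these data alone, what remains open is whether methyl is special or whether an ethyl group, a longer chain or an acetyl group on the same oxygen would move the number as far, and whether a fluorine atom in place of the whole hydroxy group would do the same. As far as these compounds go, it is also open whether the same change on the hydroxy group of compound 2 would give a step of similar size, or whether this one belongs to the core of compound 1 alone.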